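Adding a Second Methoxy Group to Compound 1

A few compounds are considered here, and "the series" means these few. Any claim that something is new, unique, unknown or untested is made for them only; others in the source may bear on it.

Compound 1 `COc1cccc(OC2=C(Cl)C(=O)c3c(OC(C)=O)ccc(OC(C)=O)c3C2=O)c1`: 5000 nM
Compound 2 `COc1cc(OC)cc(OC2=C(Cl)C(=O)c3c(OC)ccc(OC)c3C2=O)c1`: 2000 nM

In a functional assay on SCLC cells (Homo sapiens) for cytotoxicity (on this read-out higher numbers stand for weaker inhibition and lower numbers for stronger inhibition), compound 1 gives 5000 nM, the highest of the two numbers; compound 2 gives 2000 nM, a lower number, with a gap beyond the scatter. Compound 3 `COc1cc(OC)cc(OC2=C(Cl)C(=O)c3c(OC(C)=O)ccc(OC(C)=O)c3C2=O)c1` is not yet measured. It differs from compound 1 by methoxy in place of hydrogen on an aromatic carbon. Among the compounds with values here, no single-change step between measured compounds is known; compound 2 carries this second methoxy but also differs from compound 1 elsewhere. A modest downward step is expected for a 1.7-fold lower number from compound 1 to compound 3 (0.22 log units; within the scatter), near the edge of the scatter. Compound 3 is estimated at 3000 nM, ranging from 1200 nM to 8000 nM.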

Compound 3, half-maximal inhibitory concentration: 1100 nM
Estimate against measurement, compound 3: 2.7-fold (0.44 log units) above; measured number outside the range, below it.
By their numbers in this assay, from the lowest: compounds 3 and 2 (each within the scatter of the next); then compound 1.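

In this assay, within the data shown here, the change from 3-methoxyphenyl to 3,5-dimethoxyphenyl gives a 4.5-fold lower number from compound 1 to compound 3 (0.66 log units; beyond the scatter) and is the first single-change step available here. It shows that the added methoxy group, on a ring already carrying one methoxy group, lowers the number by itself, with the rest of the core of compound 1 unchanged. No measurement on hand accounts for the size of this step. The compounds shown leave open whether a hydroxy group, an ethoxy group or an amine at this carbon would give a similar step.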